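The compounds below may be only part of what the source reports. "The series", "measured", "known", "first", "only" and "open" are said of these compounds alone.

Measured in a functional assay on K562 cells (Homo sapiens) for cytotoxicity, read by MTT assay, with a stated time of 48 h; a higher number here means a weaker inhibitor, a lower number a stronger inhibitor:
- compound 1 `O=C(CN[C@H]1CCN(S(=O)(=O)Cc2ccccc2)C1)N1CCN(Cc2ccccc2F)CC1`: 12600 nM
- compound 2 `O=C(CN[C@H]1CCN(S(=O)(=O)Cc2ccccc2)C1)N1CCN(Cc2cccc(F)c2)CC1`: 13200 nM
- compound 3 `O=C(CN[C@H]1CCN(S(=O)(=O)Cc2ccccc2)C1)N1CCN(Cc2cccc(C(F)(F)F)c2)CC1`: 3600 nM

Of these three, compound 3 has the lowest number, 3600 nM, and it stands apart from both others: the data show a 3.5-fold lower number from compound 1 to compound 3 (0.54 log units; beyond the scatter) and a 3.7-fold lower number from compound 2 to compound 3 (0.56 log units; beyond the scatter). The two fluorinated compounds do not separate, with a 1.0-fold higher number from compound 1 to compound 2 (0.02 log units; within the scatter).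

Compound 4 `COc1cccc(CN2CCN(C(=O)CN[C@H]3CCN(S(=O)(=O)Cc4ccccc4)C3)CC2)c1` keeps the shared core of compound 3 and changes one group: methoxy in place of trifluoromethyl on an aromatic carbon. In words, methoxy stands in place of trifluoromethyl on an aromatic carbon, so 3-(trifluoromethyl)benzyl becomes 3-methoxybenzyl.

Within the data shown here, no measured compound carries methoxy, so no step speaks to that group directly. The closest guide is a 3.7-fold lower number from compound 2 to compound 3 (0.56 log units; beyond the scatter), a modest change made by swapping the group at this same place. That step shows that the low number of compound 3 goes with its trifluoromethyl group, which compound 4 gives up. In this assay, among the measured compounds shown here, a modest move towards higher numbers is therefore expected, probably no larger than that step, though a result near compound 3 remains possible. The expected step is a 2.2-fold higher number from compound 3 to compound 4 (0.35 log units; beyond the scatter). The estimate for compound 4 is 8000 nM, with an expected range from 3500 nM to 17000 nM.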

Compound 4, half-maximal inhibitory concentration: 60800 nM
Estimate against measurement, compound 4: 7.6-fold (0.88 log units) below; the measured number lies above the stated range.
By their numbers in this assay, from the lowest: compound 3; then compounds 1 and 2 (each within the scatter of the next); then compound 4.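

In this assay, the aromatic carbon that carries these groups proves more sensitive than the fluoro and trifluoromethyl compounds alone could show, with a 17-fold higher number from compound 3 to compound 4 (1.23 log units; beyond the scatter) for methoxy in place of trifluoromethyl, a large step that exceeds the modest 3.7-fold lower number from compound 2 to compound 3 (0.56 log units; beyond the scatter) seen before. Methoxy also falls clearly apart from fluoro, with a 4.6-fold higher number from compound 2 to compound 4 (0.66 log units; beyond the scatter) at this same place, and the comparison with the 2-fluorophenyl compound gives a 4.8-fold higher number from compound 1 to compound 4 (0.68 log units; beyond the scatter) as well, so compound 4 is the weakest of the four and the three groups at this position give three separate levels, with trifluoromethyl lowest, fluoro in the middle and methoxy highest. Nothing given here explains this order of the groups.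

The compounds shown leave open whether other groups at this place, such as an amine, a hydroxyl or a carboxylic acid, would fall within this span or outside it. They also leave open whether methoxy would give a similar result at another carbon of the aromatic ring, and whether trifluoromethyl would keep its low number there.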